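Swapping 2,3-dichlorophenyl for 4-iodophenyl on compound 1

This account rests on a few compounds, and the source may have more. Where it says the series, first, only, none or still open, it means among the compounds named here.

Among the measured compounds shown here, only two compounds have been measured so far. In a functional assay (strain AB) with Danio rerio as the target, read by microscopy, with a stated time of 1 h (a higher number here means that more compound is needed for the effect, a lower number that less compound is needed), compound 1 `CCN1CCc2c(sc(NC(=O)Nc3cccc(Cl)c3Cl)c2C(N)=O)C1` gives 17400 nM and is the higher of the two numbers. Compound 2 `C[N+]1(CC2CCC2)CCc2c(sc(NC(=O)Nc3ccc(Cl)cc3)c2C(N)=O)C1` gives 210 nM in this assay and so needs far less compound for the effect, a gap well beyond the usual scatter of repeat measurements.

The next compound to be tested is compound 3 `CCN1CCc2c(sc(NC(=O)Nc3ccc(I)cc3)c2C(N)=O)C1`. It keeps the core of compound 1 and carries 4-iodophenyl in place of 2,3-dichlorophenyl on an amide-type nitrogen. For the measured compounds named here, no two measured compounds differ in one place only, so no measurement shows the size of such a change on its own. Going by the values given here, the only guide is that compound 2 reaches 210 nM in the same test, which leaves plenty of room beneath compound 1. A moderate move toward a lower number is therefore expected, probably beyond the scatter, though with low confidence. The estimated step is a 5.8-fold lower number from compound 1 to compound 3 (0.76 log units; beyond the scatter) in this assay on this reasoning. For compound 3 the expected value is 3000 nM with an estimated range from 600 nM to 15000 nM in this assay when it is measured.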

Compound 3, half-maximal effective concentration: 1620 nM
For compound 3 the middle estimate is 1.9-fold (0.27 log units) above the measured one; low and high end bracket the measured number.
By their numbers in this assay, from the lowest: compound 2; then compound 3; then compound 1.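

In this assay, among the compounds shown here, with the core of compound 1 kept, placing 4-iodophenyl instead of 2,3-dichlorophenyl on the amide-type nitrogen gives an 11-fold lower number from compound 1 to compound 3 (1.03 log units; beyond the scatter), the first direct reading of a change at this position. The group on this nitrogen can therefore shift the number by a large amount on its own, even though the two groups match in their aromatic ring, hydrogen-bond donor and acceptor counts and net charge, and differ in their halogens, two chlorine atoms leaving and one iodine atom entering. No measurement available here accounts for the size of this step or ties it to any property of either group.

The compounds shown leave open whether the step comes from gaining the iodine or from losing the two chlorine atoms, a question that a plain phenyl group on the same nitrogen of the core of compound 1 would help to separate. Compound 2 differs from compound 1 and compound 3 in more than one place, so its steps to them cannot be read.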